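The compounds below may be only part of what the source reports. "The series", "measured", "known", "first", "only" and "open" are said of these compounds alone.

Compound 1 `Cc1ccc(C(=O)Nc2cccc(-c3oc4cc(-c5ccc(F)cc5)ccc4c(=O)c3O)c2)cc1` gives 4350 nM in a functional assay on MDA-MB-231 cells (Homo sapiens) for antiproliferative activity, read by CCK-8 assay, with a stated time of 72 h (on this read-out lower numbers stand for stronger inhibition and higher numbers for weaker inhibition), the lowest of the two numbers measured here. Compound 2 `O=C(Nc1cccc(-c2oc3cc(-c4ccc(F)cc4)ccc3c(=O)c2O)c1)c1ccc(Br)cc1` gives 24900 nM, and the step of a 5.7-fold higher number from compound 1 to compound 2 (0.76 log units; beyond the scatter) accompanies bromo in place of methyl on an aromatic carbon. Compound 3 `COc1cccc(C(=O)Nc2cccc(-c3oc4cc(-c5ccc(F)cc5)ccc4c(=O)c3O)c2)c1` differs from compound 1 by 3-methoxyphenyl in place of 4-methylphenyl on a carbonyl carbon. For the measured compounds named here, only that one measured step bears on this change, and it too alters the outer ring attached to the carbonyl, so a modest weakening is the expected direction, though the groups differ. Compound 3 is therefore expected to give 8000 nM, within 2500 nM to 25000 nM. That estimate means an expected step of a 1.8-fold higher number from compound 1 to compound 3 (0.26 log units; within the scatter).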

Compound 3, half-maximal inhibitory concentration: 9160 nM
Beside the measured number, compound 3's estimate is 1.1-fold (0.06 log units) below it; the range from low to high includes it.
By their numbers in this assay, from the lowest: compound 1; then compound 3; then compound 2.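

Placing 3-methoxyphenyl on the carbonyl carbon gives weaker inhibition than 4-methylphenyl (a 2.1-fold higher number from compound 1 to compound 3 (0.32 log units; beyond the scatter)) but stronger inhibition than 4-bromophenyl (a 2.7-fold lower number from compound 2 to compound 3 (0.43 log units; beyond the scatter)). The new compound therefore falls between the earlier two, showing that a ring with its group in a different place and an added hydrogen-bond acceptor still falls within the range they set. No available evidence explains this order.

Because the group and its ring location change together, their contributions cannot be separated. A direct comparison would need 4-methoxyphenyl, while 4-aminophenyl would test an amine here.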